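A few compounds are considered here, and "the series" means these few. Any claim that something is new, unique, unknown or untested is made for them only; others in the source may bear on it.

Of the compounds shown here, three have so far been tested in an ADME assay on BaF3 cells (Mus musculus) for cytotoxicity; on this read-out higher numbers stand for an effect only at larger amounts of compound and lower numbers for an effect already at smaller amounts. Compound 1 `COC(=O)c1cc2c(Nc3ccc(OC(F)(F)F)cc3)ncnc2s1` gives > 10000 nM in this assay, a limit of the assay rather than a number. Compound 2 `NC(=O)c1ccc(Cn2ncc3c(Nc4ccc(OC(F)(F)F)cc4)ncnc32)cc1` also gives > 10000 nM in this assay, again a limit and not a number. Compound 3 `NC(=O)c1cccc(Oc2cc(Nc3ccc(OC(F)(F)F)cc3)ncn2)c1` gives > 10000 nM in this assay, likewise only a limit. Within the data shown here, compound 2 therefore stands where every value shown stands, at the limit of > 10000 nM in this assay, at which 3 of the 3 values shown sit, so no ordering among the three can be drawn from these results, and no step between measured compounds is available.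

The compound next in line is compound 4 `CCn1ncc2c(Nc3ccc(OC(F)(F)F)cc3)ncnc21`, which differs from compound 2 in one place: methyl in place of 4-carbamoylphenyl on a saturated chain carbon bound to an aromatic nitrogen. Since all three measured compounds sit at the same limit, nothing in the data points to a step in either direction beyond the usual scatter of this assay, and the step from compound 2 to compound 4 is expected to be a step that the limit leaves unreadable from compound 2 to compound 4, that is, essentially none. Compound 4 is accordingly expected to show an effect only at large amounts, with an estimated value of 20000 nM, lying between 8000 nM and 60000 nM, most likely reported once more as a limit.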

Compound 4, half-maximal effective concentration: > 10000 nM
Compound 4: only a limit was reported (the forecaster's own chance of this, stated with the estimate: 85%); the middle value does not contradict the limit.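

No new step can be read in this assay: compound 2 and compound 4 each give only a limit of the assay, so the change from 4-carbamoylbenzyl to ethyl has no readable size. The compounds shown leave open at what concentration any of them would show an effect, because all stand together: the limit of > 10000 nM in this assay, at which 4 of the 4 values shown sit.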